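Dropping the Cyano Group: What to Expect for Compound 4

The compounds below may be only part of what the source reports. "The series", "measured", "known", "first", "only" and "open" are said of these compounds alone.

Compound 1 `CC(C)(C)c1ccc(NC(=O)C2=CCN(c3ncccc3C(F)(F)F)CC2)cc1`: 6 nM
Compound 2 `O=C(Nc1ccc(Cl)cc1F)C1=CCN(c2ncccc2Cl)CC1`: 618 nM
Compound 3 `CC(C)(C)c1ccc(NC(=O)C2=CCN(c3ncccc3C#N)CC2)cc1`: 78 nM

In an in vitro functional assay on 1321-N1 cells for antagonist activity at transient receptor potential cation channel subfamily V member 1 (Homo sapiens), read by FLIPR and calcium flux (on this read-out lower numbers stand for stronger inhibition and higher numbers for weaker inhibition), compound 3 stands second highest of the three numbers: its nearest neighbour is compound 2 at 618 nM, and the furthest is compound 1 at 6 nM. Compound 4 `CC(C)(C)c1ccc(NC(=O)C2=CCN(c3ccccn3)CC2)cc1` differs from compound 3 by hydrogen in place of cyano on an aromatic carbon. For the measured compounds named here, no measured pair covers this exact change; the one measured step at this position, a 13-fold higher number from compound 1 to compound 3 (1.11 log units; beyond the scatter), shows that the group on that carbon moves the number a great deal. Without any substituent there, compound 4 is expected to give a higher number than compound 3, with a 3.2-fold higher number from compound 3 to compound 4 (0.51 log units; beyond the scatter) the estimated size of the step. The estimate for compound 4 is 250 nM, with a likely range from 60 nM to 1000 nM.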

Compound 4, half-maximal inhibitory concentration: 27 nM
Estimate against measurement, compound 4: 9.3-fold (0.97 log units) above; the measured number lies below the stated range.
By their numbers in this assay, from the lowest: compound 1; then compound 4; then compound 3; then compound 2.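

In this assay the loss of cyano does not cost inhibition: the change gives a 2.9-fold lower number from compound 3 to compound 4 (0.46 log units; beyond the scatter) and so places hydrogen ahead of cyano on this carbon. The other comparison gives a 4.5-fold higher number from compound 1 to compound 4 (0.65 log units; beyond the scatter) and so keeps trifluoromethyl ahead of hydrogen. The two groups therefore fall on opposite sides of the unsubstituted compound 4, and a substituent here can either strengthen or weaken inhibition.

On these data alone, whether a methyl, a methoxy or an amine on this carbon would fall nearer compound 1 or compound 3 stays open. Nothing at hand explains this order.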